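The compounds below may be only part of what the source reports. "The series", "measured", "known", "first", "only" and "open" are said of these compounds alone.

Working notes on the series built on the core of compound 1 `COc1ccc(S(=O)(=O)N2CCc3cccc(-c4ccc(N(C)C)cc4)c32)cc1`. Among the measured compounds shown here, in a functional assay on KB cells (Homo sapiens) for inhibition, with a stated time of 72 h (on this read-out lower numbers stand for stronger inhibition and higher numbers for weaker inhibition), compound 1 gives 539 nM, the second highest of the three numbers so far. Compound 3 `COc1ccc(S(=O)(=O)N2CCc3cccc(-c4ccncc4)c32)cc1` gives 96 nM, and compound 2 `COc1ccc(S(=O)(=O)N2CCc3cccc(-c4cc(OC)c(OC)c(OC)c4)c32)cc1` gives 3690 nM.

The next case is compound 4 `COc1ccc(S(=O)(=O)N2CCc3cccc(-c4cccnc4)c32)cc1`, with pyridin-3-yl in place of 4-(dimethylamino)phenyl on an aromatic carbon. For the measured compounds named here, one measured step bears on this change: a 5.6-fold lower number from compound 1 to compound 3 (0.75 log units; beyond the scatter), a modest move beyond the scatter, with pyridin-4-yl replacing the same group. Going by the values given here, no measured compound yet shows how pyridin-3-yl compares with pyridin-4-yl, so that step is only a guide. A step in the same direction but somewhat smaller is expected in this assay, which would still be a lower number than that of compound 1. The expected move is a 3.6-fold lower number from compound 1 to compound 4 (0.56 log units; beyond the scatter). Compound 4 is estimated at 150 nM, with an expected range of 50 nM to 450 nM.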

Compound 4, half-maximal inhibitory concentration: 95.9 nM
Beside the measured number, compound 4's estimate is 1.6-fold (0.19 log units) above it; the measured number falls inside the stated range.
By their numbers in this assay, from the lowest: compounds 4 and 3 (each within the scatter of the next); then compound 1; then compound 2.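

In this assay, pyridin-3-yl in place of pyridin-4-yl gives a 1.0-fold lower number from compound 3 to compound 4 (0.00 log units; within the scatter), so at this aromatic carbon of the shared core the read-out does not separate these two pyridine groups. Pyridin-3-yl in place of 4-(dimethylamino)phenyl gives a 5.6-fold lower number from compound 1 to compound 4 (0.75 log units; beyond the scatter), matching a 5.6-fold lower number from compound 1 to compound 3 (0.75 log units; beyond the scatter), so the lower number relative to compound 1 now holds for two pyridine groups rather than one. Nothing available explains why the two pyridine groups read alike.

The compounds shown leave open whether pyridin-2-yl would fall in the same range as compound 3 and compound 4. Also open, from the compounds shown here alone, is how an unsubstituted phenyl ring, or a pyridine ring carrying an amine or a methoxy group, would read at this carbon.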